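The source may report more compounds than this note shows. Statements on the series, on what has been measured and on what is new or still open speak of the compounds shown alone.

Working notes on the series. In a physicochemical assay for solubility, read by HPLC, in phosphate buffer, measured as kinetic solubility, at pH 7.4 (a lower number here means a less soluble compound, a higher number a more soluble compound), compound 1 `Cc1c(C(=O)O)cc(-c2ccc(F)cc2)n1-c1ccc(S(N)(=O)=O)cc1` gives 50000 nM and compound 2 `CCC(=O)c1cc(-c2ccc(S(N)(=O)=O)cc2)n(-c2ccc(Cl)cc2)n1` gives 41900 nM. These two values lie within the scatter of each other, so compound 2 stands level with compound 1 on the numbers available.

Compound 3 `CCCC(=O)c1cc(-c2ccc(S(N)(=O)=O)cc2)n(-c2ccc(Cl)cc2)n1` departs from compound 2 in one place: methyl in place of hydrogen on a saturated chain carbon, two bonds along the chain from a carbonyl carbon. This is methyl in place of hydrogen on a saturated chain carbon, two bonds along the chain from a carbonyl carbon, which turns propanoyl into propylcarbonyl.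

Among the measured compounds shown here, the two measured compounds differ in more than one place, so the series offers no measured step of this kind to calibrate against. The expectation therefore rests on the structural change alone, and it is modest: a small downward move in this assay, one that may not clear the scatter. The anchor for the estimate is compound 2 at 41900 nM. The expected change is a 1.5-fold lower number from compound 2 to compound 3 (0.18 log units; within the scatter). For compound 3 the estimated solubility is 28000 nM, with an expected range of 11000 nM to 50000 nM.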

Compound 3, solubility: 25800 nM
For compound 3 the middle estimate is 1.1-fold (0.04 log units) above the measured one; the measured number falls inside the stated range.
By their numbers in this assay, from the lowest: compounds 3, 2 and 1 (each within the scatter of the next).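

Among the compounds shown here, this is the first step that can be read in one place: methyl in place of hydrogen on a saturated chain carbon, two bonds along the chain from a carbonyl carbon, gives in this assay a 1.6-fold lower number from compound 2 to compound 3 (0.21 log units; within the scatter) on the shared core. On this single step, going from propanoyl to propylcarbonyl at this place does not separate the two compounds beyond what repeated measurements would give, something the earlier pair, which differs in more than one place, could not show. Nothing available bears on the reason for this reading.

On these data alone, with a single step at this place, it remains open whether the reading holds for a longer chain such as butyl or for a branched group such as isopropyl on the same carbonyl. As far as these compounds go, it also remains open how a polar group in the same place, such as an amine or a carboxylic acid at the end of the chain, would read in this assay on this core.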